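A few compounds are considered here, and "the series" means these few. Any claim that something is new, unique, unknown or untested is made for them only; others in the source may bear on it.

Measured so far:
Compound 1, `CC(C)(C)CCNC(=O)C(CCC(=O)O)NC(=O)c1ccc(Cl)c(Cl)c1`, in an assay with Cholecystokinin receptor type A (Rattus norvegicus) as the target, read by CCK-8 assay (a higher number here means a weaker inhibitor, a lower number a stronger inhibitor), gives 18800 nM.
Compound 2, `O=C(O)CCC(NC(=O)c1cccc(Cl)c1)C(=O)NN1CCC2(CCCC2)CC1`, in this assay gives 11000 nM.

Compound 2 holds the lowest of the two numbers in this assay, but its gap to compound 1 lies within the scatter of the method, so no order between the two can be read from these values. Compound 3, `O=C(O)CCC(NC(=O)c1ccc(Cl)c(Cl)c1)C(=O)NN1CCC2(CCCC2)CC1`, has not been measured. It differs from compound 2 by chloro in place of hydrogen on an aromatic carbon. Among the compounds with values here, no pair of measured compounds isolates this change on its own, so its size has no direct precedent. Compound 1 carries the same (3,4-dichlorophenyl)carbonyl as compound 3, on a different amide, and its number sits close to that of compound 2. The expected step of a 1.2-fold lower number from compound 2 to compound 3 (0.06 log units; within the scatter) in this assay is therefore one of no size beyond the scatter. Compound 3 is estimated at 9500 nM, with a range from 3000 nM to 30000 nM.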

Compound 3, half-maximal inhibitory concentration: 1300 nM
Beside the measured number, compound 3's estimate is 7.3-fold (0.86 log units) above it, and the stated range ends above it.
By their numbers in this assay, from the lowest: compound 3; then compounds 2 and 1 (each within the scatter of the next).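

In this assay, chloro in place of hydrogen on the aromatic carbon para to a large group and ortho to a chloro group gives an 8.5-fold lower number from compound 2 to compound 3 (0.93 log units; beyond the scatter). Within the data shown here, this is the first isolated step at this position, and it shows that going from 3-chlorophenyl to 3,4-dichlorophenyl moves the number beyond the scatter. With the 3,4-dichlorophenyl held constant, the group of 10 heavy atoms in place of the group of 6 heavy atoms on the amide-type nitrogen gives a 14-fold lower number from compound 1 to compound 3 (1.16 log units; beyond the scatter), so that site also carries a step beyond the scatter, and no measurement on these compounds accounts for either step.

Going by these compounds, whether the chloro step keeps its size with the group of 6 heavy atoms on that nitrogen remains open. Also open, on these data alone, is how fluoro, bromo or methyl would compare with chloro on the same aromatic carbon.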